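Swapping an Aryl Group in a Chemokine Receptor Series

This account rests on a few compounds, and the source may have more. Where it says the series, first, only, none or still open, it means among the compounds named here.

Two compounds have been measured in an assay on blood for inhibition of C-X-C chemokine receptor type 3 (Homo sapiens), with a stated time of 30 min; on this read-out higher numbers stand for weaker inhibition and lower numbers for stronger inhibition:

compound 1 `C[C@@H]1CN(c2sc(C3COC3)nc2-c2nc3ccccc3[nH]2)CCN1C(=O)Cn1cnc2cccnc21`: 1150 nM
compound 2 `COc1ccc(-c2nc(C(F)(F)F)sc2N2CCN(C(=O)Cn3cnc4cccnc43)[C@H](C)C2)cc1`: 1190 nM

Of the two numbers, compound 2 gives nominally the higher, but compound 1 lies so close that the gap falls within the usual scatter, so no real difference between them is shown.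

Compound 3 `CCOc1ncc(-c2nc(C(F)(F)F)sc2N2CCN(C(=O)Cn3cnc4cccnc43)[C@H](C)C2)cn1` has not yet been measured. It differs from compound 2 in a single place: 2-ethoxypyrimidin-5-yl in place of 4-methoxyphenyl on an aromatic carbon. Among the compounds with values here, no pair of measured compounds differs in this way, so nothing here sets the size or direction of that change. With both measured values close together and no guide to the change, the expected step in this assay is a 1.1-fold higher number from compound 2 to compound 3 (0.04 log units; within the scatter), that is, none beyond the scatter. On that basis compound 3 is estimated at 1300 nM, with a range from 500 nM to 3500 nM.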

Compound 3, half-maximal inhibitory concentration: 48 nM
For compound 3 the middle estimate is 27-fold (1.43 log units) above the measured one; the measured number lies below the stated range.
By their numbers in this assay, from the lowest: compound 3; then compounds 1 and 2 (each within the scatter of the next).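

In this assay, the group on this aromatic carbon of the five-membered ring turns out to matter a great deal: 2-ethoxypyrimidin-5-yl in place of 4-methoxyphenyl gives a 25-fold lower number from compound 2 to compound 3 (1.39 log units; beyond the scatter). The swap alters two things at once, the six-membered ring, which gains 2 hetero atoms, and the chain on oxygen, which goes from methoxy to ethoxy, so this one step cannot divide the gain between them. Nothing available here accounts for the size of the gain.

Open, from the compounds shown here alone, is whether 4-ethoxyphenyl or 2-methoxypyrimidin-5-yl would keep the gain, which would separate the ring from the chain. Also open, going by these compounds, is whether the gain would hold with a nitrile or a methyl group in place of trifluoromethyl.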